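Methyl for Methoxy: A Small Change on the Benzamide

The compounds below may be only part of what the source reports. "The series", "measured", "known", "first", "only" and "open" are said of these compounds alone.

Compound 1 `COc1cc2ncnc(NNC(=S)NC(=O)c3ccc(Cl)cc3)c2cc1OC` gives 7530 nM in a functional assay on CNE-2 cells (Homo sapiens) for cytotoxicity, read by MTT assay, with a stated time of 72 h; a higher number here means a weaker inhibitor, a lower number a stronger inhibitor.
Compound 2 `COc1ccccc1C(=O)NC(=S)NNc1ncnc2ccccc12` gives 15700 nM in this assay.

Among the measured compounds shown here, of the two numbers so far, compound 2 carries the higher one, so it is the weaker inhibitor of the pair. The nearest value, that of compound 1, lies lower, and the gap between them is beyond the scatter of repeated measurements. Compound 1 and compound 2 differ in more than one place, so their two values show only that they sit apart; no single change can be read from them.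

Compound 3 `Cc1ccccc1C(=O)NC(=S)NNc1ncnc2ccccc12` is compound 2 with one change: methyl in place of methoxy on an aromatic carbon. For the measured compounds named here, no measured pair isolates this exchange, so there is no step on record to lean on. Because compound 2 gives 15700 nM, the expectation rests on that value alone, and the step from compound 2 to compound 3 is expected to be a 1.1-fold lower number from compound 2 to compound 3 (0.05 log units; within the scatter), with no clear direction beyond the scatter. Compound 3 is therefore estimated at 14000 nM in this assay, with a range from 5000 nM to 40000 nM.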

Compound 3, half-maximal inhibitory concentration: 5460 nM
Compound 3: the middle estimate sits 2.6-fold (0.41 log units) above what was measured; measured number inside the range.
By their numbers in this assay, from the lowest: compounds 3 and 1 (each within the scatter of the next); then compound 2.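

In this assay, among the compounds shown here, the change from 2-methoxyphenyl to 2-methylphenyl gives a 2.9-fold lower number from compound 2 to compound 3 (0.46 log units; beyond the scatter) and is the first single change on record. Where compound 1 and compound 2 could show only that they sit apart, this pair shows that the position, on an aromatic carbon ortho to a large group, responds to what it carries, with a modest step that lies beyond the scatter. The data give no measured reason for the lower number, and the hydrogen-bond acceptor that leaves with methoxy can be noted but not credited with the step.

A single pair cannot tell whether the step belongs to the arrival of methyl or to the departure of methoxy, and the compounds shown leave open how a hydroxyl group, an amine or an ethyl group on that same carbon would compare. Also open, from the compounds shown here alone, is whether the same exchange would give a similar step on the core of compound 1, which differs from compound 2 in more than one place.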